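The source may report more compounds than this note shows. Statements on the series, on what has been measured and on what is new or still open speak of the compounds shown alone.

For the measured compounds named here, in a functional assay on DU-145 cells (Homo sapiens) for inhibition, read by trypan blue exclusion, with a stated time of 72 h (a lower number here means a stronger inhibitor, a higher number a weaker inhibitor), compound 2 `Cn1c(=O)c(S(=O)(=O)c2ccc(F)cc2F)cc2cnc(NCc3ccc4[nH]ccc4c3)nc21` stands at 100000 nM, the highest of the two numbers so far, while compound 1 `Cn1ccc2cc(Nc3ncc4cc(S(=O)(=O)c5ccc(F)cc5F)c(=O)n(C)c4n3)ccc21` gives 750 nM. Compound 3 `Cn1c(=O)c(S(=O)(=O)c2ccc(F)cc2F)cc2cnc(Nc3ccc4c(c3)C(=O)C(=O)N4)nc21` keeps the shared core and changes one group: a group of 11 heavy atoms (8 carbon, 1 nitrogen, 2 oxygen; one five-membered non-aromatic ring with 1 hetero atom, one six-membered aromatic ring of carbon only) in place of a group of 10 heavy atoms (9 carbon, 1 nitrogen; one five-membered aromatic ring with 1 hetero atom, one six-membered aromatic ring of carbon only), on a nitrogen on an aromatic ring. Going by the values given here, the only measured step bearing on this is a 130-fold higher number from compound 1 to compound 2 (2.12 log units; beyond the scatter), which came with the arrival of (1H-indol-5-yl)methyl. With that single large step as a guide, much of the rise is expected to be undone when this group leaves. The expected step is a large fall, a 50-fold lower number from compound 2 to compound 3 (1.70 log units; beyond the scatter). For compound 3 the estimate is 2000 nM, within an expected range of 250 nM to 20000 nM.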

Compound 3, half-maximal inhibitory concentration: 75000 nM
Compound 3: middle estimate off by 38-fold (1.57 log units), on the low side; the measured number lies above the stated range.
By their numbers in this assay, from the lowest: compound 1; then compounds 3 and 2 (each within the scatter of the next).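

In this assay the step of a 1.3-fold lower number from compound 2 to compound 3 (0.12 log units; within the scatter) leaves the two compounds indistinguishable, while the step of a 100-fold higher number from compound 1 to compound 3 (2.00 log units; beyond the scatter) stays large. Two quite different groups on this nitrogen, (1H-indol-5-yl)methyl and the one with the five-membered non-aromatic ring, thus give matching numbers, and among the three compounds only 1-methyl-1H-indol-5-yl stands clearly apart from them. No evidence at hand accounts for this. Open, on these data alone, is how much of the difference rests on the methyl of 1-methyl-1H-indol-5-yl. Plain 1H-indol-5-yl, or a phenyl bearing an amine or a carboxylic acid, would test how narrow this position is.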